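The source may hold more compounds than are shown below. What is called first, only, known or untested is meant among the compounds shown, and "the series" means these compounds.

Working notes, antiproliferative series, step from compound 2 to compound 4.

Measured in a functional assay on MCF7 cells (Homo sapiens) for antiproliferative activity, read by crystal violet staining, with a stated time of 96 h; on this read-out lower numbers stand for stronger inhibition and higher numbers for weaker inhibition:
- compound 1 `C[C@@H]1O[C@H](N2C(=O)/C(=C3\Nc4ccccc4C3=O)c3ccccc32)[C@H](O)[C@H](O)[C@H]1O` gives 760 nM
- compound 2 `O=C1/C(=C2/C(=O)N([C@@H]3O[C@H](CO)[C@H](O)[C@H](O)[C@H]3O)c3ccccc32)Nc2ccccc21` gives 25800 nM
- compound 3 `Cc1cc(C)c2c(c1)N([C@H]1O[C@@H](C)[C@H](O)[C@@H](O)[C@H]1O)C(=O)/C2=C1\Nc2ccccc2C1=O` gives 6160 nM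

Compound 2 stands at the highest number of the three in this assay, that is, the weakest inhibition recorded so far. Its nearest neighbour is compound 3, and the gap between the two values lies beyond the usual scatter; the gap to compound 1 is wider still, also beyond the scatter. Going by the values given here, no pair of measured compounds differs in only one place, so no measured step is available to calibrate the change considered here.

Compound 4 `O=C1/C(=C2/C(=O)N([C@@H]3O[C@H](CO)[C@@H](O)[C@H](O)[C@@H]3O)c3ccccc32)Nc2ccccc21` has not yet been measured. Relative to compound 2 the change is: the two compounds have the same atoms and bonds and differ only in configuration as drawn: 2 of 6 stereo elements differ; a stereocentre at a saturated ring carbon is drawn R in compound 2 and S in compound 4; a stereocentre at a saturated ring carbon is drawn R in compound 2 and S in compound 4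

With no measured step of this kind in the series, the expectation for the step from compound 2 to compound 4 is a small one, in either direction, and most likely none beyond the scatter, so that a 1.2-fold lower number from compound 2 to compound 4 (0.07 log units; within the scatter) is the expected move. On that basis compound 4 is estimated at 22000 nM, with a range from 7000 nM to 70000 nM.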

Compound 4, half-maximal inhibitory concentration: 4220 nM
Estimate against measurement, compound 4: 5.2-fold (0.72 log units) above; measured number outside the range, below it.
By their numbers in this assay, from the lowest: compound 1; then compounds 4 and 3 (each within the scatter of the next); then compound 2.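

In this assay the series now has its first measured step, a 6.1-fold lower number from compound 2 to compound 4 (0.79 log units; beyond the scatter) and it lies beyond the scatter with nothing entering or leaving. Going by these compounds alone, the drawn configuration at saturated ring carbons is therefore enough to shift this read-out, which the earlier compounds, all differing in more than one place, could not show. The shift can be assigned to configuration alone because nothing else separates the pair: the fact that compounds 2 and 4 differ only in the configuration as drawn.

Both stereocentres change together, so the compounds shown do not tell whether one of them carries the step or both are needed. Also open, on these data alone, is whether the same inversion would move the read-out in the same direction with an amine or a carboxylic acid on the ring that holds these stereocentres.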